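This account rests on a few compounds, and the source may have more. Where it says the series, first, only, none or still open, it means among the compounds named here.

Compound 1 `Cc1cc(C)cc(NC(=O)COc2cc(C)nc3ccc(C(F)(F)F)cc23)c1`: > 100000 nM
Compound 2 `COc1ccc2nc(C)cc(OC(C)C(=O)Nc3cc(C)cc(C)c3)c2c1`: 39800 nM
Compound 3 `COc1ccc2nc(C)cc(OCC(=O)Nc3ccccc3)c2c1`: 39800 nM

Of the compounds shown here, three have so far been tested in a toxicity assay on HepG2 cells (Homo sapiens) for inhibition, read by CellTiter-Glo, with a stated time of 48 h; on this read-out higher numbers stand for weaker inhibition and lower numbers for stronger inhibition. For compound 1 the result is a limit of the assay, (the limit of > 100000 nM in this assay, at which 1 of the 3 values shown sits), so no number stands for it. Compound 2 gives 39800 nM. Compound 3 gives 39800 nM, which is level with compound 2 at the digits shown and within the usual scatter, so no order can be read between these two. Compound 4 `COc1ccc2nc(C)cc(OCC(=O)Nc3ccc(Cl)cc3)c2c1` has not yet been measured. It differs from compound 3 in a single place: chloro in place of hydrogen on an aromatic carbon. Among the measured compounds shown here, no two measured compounds differ by only one change, so the size of such a step has not been seen in this set. The expectation in this assay is a small step toward stronger inhibition, if any, one that may well stay within the scatter. The step from compound 3 to compound 4 is expected to be a 1.6-fold lower number from compound 3 to compound 4 (0.20 log units; within the scatter). Compound 4 is estimated at 25000 nM, with a range from 8000 nM to 80000 nM.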

Compound 4, half-maximal inhibitory concentration: > 100000 nM
Compound 4: no number, only a limit (the forecaster's own chance of this, stated with the estimate: 15%); middle value at least 4.0-fold (0.60 log units) away from the limit.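

Among the compounds shown here, this pair is the first in the set to differ in one place only, so it gives the first view of how large a single change can be in this assay. Chloro in place of hydrogen on an aromatic carbon, para to a large group, gives an at least 2.5-fold higher number from compound 3 to compound 4 (0.40 log units; beyond the scatter), so on this phenyl ring the change moves toward weaker inhibition and beyond the usual scatter. The true size of the step cannot be read, since compound 4 sits at a limit of the assay and has no number: the limit of > 100000 nM in this assay, at which 2 of the 4 values shown sit.

As far as these compounds go, it remains open whether another group at this place, such as a fluoro, a methoxy or an amine, would shift the value in the same way. A single pair also cannot tell whether chloro would do the same on the core of compound 1.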